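Exchanging the Aryl Group on the Chain: What to Expect

The source may hold more compounds than are shown below. What is called first, only, known or untested is meant among the compounds shown, and "the series" means these compounds.

Of the compounds shown here, three sharing one core have been tested in an ADME assay on the whole organism for cytotoxicity, with Artemia salina as the target, with a stated time of 24 h; on this read-out higher numbers stand for an effect only at larger amounts of compound and lower numbers for an effect already at smaller amounts. Compound 1 `COc1cccc(/C=C/C(=O)c2ccccc2NC(=O)NS(=O)(=O)c2ccc(C)cc2)c1` gives 23.2 ug/mL in this assay. Compound 2 `CCc1cc(/C=C/C(=O)c2ccccc2NC(=O)NS(=O)(=O)c2ccc(C)cc2)cc(OC)c1OC` gives 19.2 ug/mL, and compound 3 `CCOc1cc(/C=C/C(=O)c2ccccc2NC(=O)NS(=O)(=O)c2ccc(C)cc2)ccc1O` gives 19.2 ug/mL. Compound 3 thus stands level with compound 2 at the digits shown, the two together being the lowest of the three numbers, while the remaining gap is small: a 1.2-fold lower number from compound 1 to compound 3 (0.08 log units; within the scatter). The remaining changes of the same aryl group were also small: a 1.2-fold lower number from compound 1 to compound 2 (0.08 log units; within the scatter) and no change at the digits printed from compound 2 to compound 3 (within the scatter).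

Compound 4 `Cc1ccc(S(=O)(=O)NC(=O)Nc2ccccc2C(=O)/C=C/c2cccc(Br)c2)cc1` differs from compound 3 in one place: 3-bromophenyl in place of 3-ethoxy-4-hydroxyphenyl on a double-bonded chain carbon bound to a double-bonded chain carbon. The three measured steps all exchange the aryl group on the double-bonded chain carbon, and none of them moved the number beyond the scatter. Going by the values given here, no measured pair brings in a bromine, so these three steps are the only guide available. The expectation for compound 4 is therefore a step of a 1.0-fold higher number from compound 3 to compound 4 (0.02 log units; within the scatter), which means no change beyond the scatter. Compound 4 is estimated at 20 ug/mL, with a range from 10 ug/mL to 40 ug/mL.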

Compound 4, concentration for half-maximal effect: 4.02 ug/mL
Beside the measured number, compound 4's estimate is 5.0-fold (0.70 log units) above it, outside the stated range (below it).
By their numbers in this assay, from the lowest: compound 4; then compounds 2, 3 and 1 (each within the scatter of the next).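

In this assay, the aryl group on the double-bonded chain carbon proves able to move the number beyond the scatter, which none of the earlier exchanges did: 3-bromophenyl in place of 3-ethoxy-4-hydroxyphenyl gives a 4.8-fold lower number from compound 3 to compound 4 (0.68 log units; beyond the scatter), and in place of 3-ethyl-4,5-dimethoxyphenyl it gives a 4.8-fold lower number from compound 2 to compound 4 (0.68 log units; beyond the scatter). The narrowest exchange, bromo in place of methoxy on an aromatic carbon, gives a 5.8-fold lower number from compound 1 to compound 4 (0.76 log units; beyond the scatter), so changing one substituent on this aryl group is enough to bring the effect down to smaller amounts of compound. No measurement available here accounts for this shift.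

Going by these compounds, whether the shift belongs to the bromine itself or to the absence of the oxygen-bearing groups stays open, as a single bromo compound cannot separate the two. Compounds with 3-chlorophenyl, 3-methylphenyl or plain phenyl on a double-bonded chain carbon bound to a double-bonded chain carbon would help to tell these readings apart, and a group carrying an amine or a carboxylic acid there would show how far the number can move in either direction.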